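Adding an amino group to compound 3

This account rests on a few compounds, and the source may have more. Where it says the series, first, only, none or still open, it means among the compounds named here.

Of the compounds shown here, three have been tested in a functional assay on CCRF-CEM cells (Homo sapiens) for cytotoxicity; on this read-out lower numbers stand for stronger inhibition and higher numbers for weaker inhibition. Compound 1 `Cc1cn([C@H]2C=C(F)[C@@H](CO)O2)c(=O)[nH]c1=O` gives > 100000 nM, which is a limit of the assay and not a number. Compound 2 `Nc1ncnc2c1ncn2[C@H]1C=C(F)[C@@H](CO)O1` gives > 100000 nM, which is also a limit. Among the compounds with values here, compound 3 `OC[C@H]1O[C@@H](n2cnc3c(O)ncnc32)C=C1F` gives 77700 nM, the only true number of the three. The picture so far is therefore set by the limit of > 100000 nM in this assay, at which 2 of the 3 values shown sit.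

Compound 4 `Nc1nc(O)c2ncn([C@H]3C=C(F)[C@@H](CO)O3)c2n1` differs from compound 3 in one place: amino in place of hydrogen on an aromatic carbon. The new amino group sits on an aromatic carbon between two ring nitrogen atoms, where compound 3 carries only a hydrogen.

Within the data shown here, only one measured step involves an amino group: an at least 1.2-fold lower number from compound 2 to compound 3 (0.10 log units; that floor lies within the scatter). That step stays within the usual scatter, and it swaps amino for hydroxy on a different carbon rather than adding a group, so it offers only weak guidance here. Among the measured compounds shown here, no measured step shows what this addition does, so no shift beyond the scatter is expected in this assay, and a result reported only as a limit would be no surprise. The expected change is a 1.0-fold higher number from compound 3 to compound 4 (0.01 log units; within the scatter). For compound 4 the estimated value is 80000 nM, with an expected range from 35000 nM to 100000 nM.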

Compound 4, half-maximal inhibitory concentration: > 100000 nM
Compound 4: only a limit was reported (the forecaster's own chance of this, stated with the estimate: 60%); middle value at least 1.2-fold (0.09 log units) from the limit.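

Putting an amino group on the aromatic carbon between two ring nitrogen atoms, where compound 3 carries a hydrogen, gives an at least 1.2-fold higher number from compound 3 to compound 4 (0.10 log units; that floor lies within the scatter). Within the data shown here, this is the first measured change at this position in this assay, and it brings no sign of stronger inhibition, although the result for compound 4 is a limit of the assay and not a number, and the floor of the step cannot be told apart from no change. Among these compounds, compound 3 remains the only compound with a true number, and the series is still framed by a single boundary: the limit of > 100000 nM in this assay, at which 3 of the 4 values shown sit.

As far as these compounds go, how far compound 4 really lies from compound 3 stays unknown, and the amino group's true effect could be slight or much larger than the floor suggests. Also open, from the compounds shown here alone, is whether another group on this same carbon, such as a methyl, a chlorine or a longer chain like an aminoethyl, would bring the number in this assay down, towards stronger inhibition.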